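This account rests on a few compounds, and the source may have more. Where it says the series, first, only, none or still open, it means among the compounds named here.

Three compounds sharing one core were tested in a functional assay on U-373MG ATCC cells (Homo sapiens) for inhibition, read by MTT assay, with a stated time of 72 h; on this read-out higher numbers stand for weaker inhibition and lower numbers for stronger inhibition. Compound 1 `CC1(C)CC(NC(=S)Nc2ccc(C#N)cc2)c2cc(F)ccc2O1` gives 11000 nM, and compound 2 `CC1(C)CC(NC(=S)Nc2ccc(C#N)cc2)c2cc(Cl)ccc2O1` gives 10000 nM. These two differ by fluoro in place of chloro on an aromatic carbon, and the step amounts to a 1.1-fold higher number from compound 2 to compound 1 (0.04 log units; within the scatter). Compound 3 `CC1(C)CC(NC(=S)Nc2cccc([N+](=O)[O-])c2)c2cc(Cl)ccc2O1` differs from compound 2 in more than one place; the difference between the two cores is not broken down here. In this assay compound 3 gives 3000 nM, the lowest number of the three, with gaps to compound 2 and to compound 1 that lie beyond the usual scatter.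

Compound 4 `CC1(C)CC(NC(=S)Nc2cccc([N+](=O)[O-])c2)c2cc(F)ccc2O1` has not yet been measured. Among the compounds with values here, it differs from compound 3 by fluoro in place of chloro on an aromatic carbon, the same change at the same place as the one between compound 2 and compound 1. Because that earlier change gave a 1.1-fold higher number from compound 2 to compound 1 (0.04 log units; within the scatter), a step of similar size is expected, a 1.1-fold higher number from compound 3 to compound 4 (0.04 log units; within the scatter). On that basis compound 4 is estimated to give 3300 nM in this assay, most plausibly between 1500 nM and 7000 nM.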

Compound 4, half-maximal inhibitory concentration: 6000 nM
Compound 4: middle estimate off by 1.8-fold (0.26 log units), on the low side; low and high end bracket the measured number.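

In this assay, fluoro in place of chloro on an aromatic carbon gives a 2.0-fold higher number from compound 3 to compound 4 (0.30 log units; within the scatter), so on this core too the change stays within the usual scatter. The two steps do not differ by more than the scatter of such steps: the same change on two cores in this assay, a 1.1-fold higher number (0.04 log units; within the scatter) from compound 2 to compound 1 and a 2.0-fold higher number (0.30 log units; within the scatter) from compound 3 to compound 4, 1.8-fold (0.26 log units) apart, within the scatter of two such steps. Within the data shown here, this shows that, for these two cores, the change carried over without a step beyond the scatter, but it rests on only two pairs with the same change at the same place, and it does not show that the change would behave alike on other cores or at other places.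

The compounds shown leave open whether a bromo, a methyl or a methoxy group at that same place would also leave the number within the scatter of the chloro and fluoro compounds. As far as these compounds go, it also remains open how an amine or a carboxylic acid in place of the nitrile or the nitro group would read in this assay.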